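Working notes on the aryl swap toward compound 4

This account rests on a few compounds, and the source may have more. Where it says the series, first, only, none or still open, it means among the compounds named here.

The series shares one core, carried by compound 1 `Cc1ccc(-c2c(C)nn(-c3nc(-c4ccc(Cl)c(Cl)c4)c(SC(C)C)s3)c2C(=O)O)cc1`, compound 2 `COc1ccccc1-c1c(C)nn(-c2nc(-c3ccc(Cl)c(Cl)c3)c(SC(C)C)s2)c1C(=O)O` and compound 3 `Cc1nn(-c2nc(-c3ccc(Cl)c(Cl)c3)c(SC(C)C)s2)c(C(=O)O)c1-c1ccncc1`, and varies only in the aromatic group on the five-membered aromatic ring with 2 nitrogen. In a functional assay on BJAB cells (Homo sapiens) for antiproliferative activity, with a stated time of 4 days (a higher number here means that more compound is needed for the effect, a lower number that less compound is needed), compound 1 gives 3800 nM, compound 2 gives 14700 nM and compound 3 gives 5900 nM. Compound 3 thus stands second highest of the three numbers: its nearest neighbour is compound 1, which lies within the scatter, while compound 2 stands farther off, with a 2.5-fold lower number from compound 2 to compound 3 (0.40 log units; beyond the scatter). The remaining steps at this position are a 1.6-fold higher number from compound 1 to compound 3 (0.19 log units; within the scatter) and a 3.9-fold higher number from compound 1 to compound 2 (0.59 log units; beyond the scatter), so the whole spread from three different aryl groups stays modest.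

Compound 4 `Cc1nn(-c2nc(-c3ccc(Cl)c(Cl)c3)c(SC(C)C)s2)c(C(=O)O)c1-c1cc(C#N)cc(C(F)(F)F)c1` continues this variation: 3-cyano-5-(trifluoromethyl)phenyl in place of pyridin-4-yl on an aromatic carbon. Among the measured compounds shown here, no measured pair carries a nitrile or a trifluoromethyl group, so the step has no direct precedent; the three changes at this position all stayed modest, and the same is expected here, with a step of a 1.2-fold lower number from compound 3 to compound 4 (0.07 log units; within the scatter) expected to lie around the scatter in either direction. For compound 4 in this assay a value near 5000 nM is therefore estimated, expected to fall between 1800 nM and 14000 nM.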

Compound 4, half-maximal effective concentration: 3600 nM
Estimate against measurement, compound 4: 1.4-fold (0.14 log units) above, and the stated range covers the measured number.
By their numbers in this assay, from the lowest: compounds 4, 1 and 3 (each within the scatter of the next); then compound 2.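

In this assay, the larger 3-cyano-5-(trifluoromethyl)phenyl group, the first at this position to carry a nitrile and a trifluoromethyl group, stays level with both pyridin-4-yl and 4-methylphenyl, with a 1.6-fold lower number from compound 3 to compound 4 (0.21 log units; within the scatter) and a 1.1-fold lower number from compound 1 to compound 4 (0.02 log units; within the scatter) as the two steps. Only the change from 2-methoxyphenyl leaves the scatter, with a 4.1-fold lower number from compound 2 to compound 4 (0.61 log units; beyond the scatter) as the largest step in the set, so compound 2 now stands apart from all three other compounds, while compounds 1, 3 and 4 cannot be ordered among themselves. Across these aryl groups, therefore, neither the carbon-only ring against the ring with a nitrogen nor the added heavy atoms of compound 4 produce a step beyond the scatter, and no supporting data are available to explain any of these steps.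

Compound 4 carries the nitrile and the trifluoromethyl group together, so the contribution of each alone remains unresolved. All four compounds keep an aromatic ring at this position, leaving open how an amine, a saturated ring such as cyclohexyl, or a longer alkyl chain would behave there.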